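A few compounds are considered here, and "the series" means these few. Any claim that something is new, unique, unknown or untested is made for them only; others in the source may bear on it.

Two measured compounds set the scene. Compound 1 `O=C(Nc1ccc(Cl)cc1)Nn1c(-c2ccccc2)nc2ccccc2c1=O` was tested in a functional assay on the whole organism (strain albino) with Mus musculus as the target, at a dose of 100 mg/kg by the intraperitoneal route (a lower number here means less inhibition, a higher number more inhibition at the dose given (going by the name of the read-out)), and in this assay compound 1 gives 55%. Compound 2 `CCc1nc2ccccc2c(=O)n1NC(=O)Nc1ccc(C)cc1` was tested under the same conditions, and in this assay compound 2 gives 55%. Compound 2 thus stands level with compound 1 at the digits reported, the two values lying within the scatter of each other, so no order between them can be read.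

The step of interest leads from compound 2 to compound 3 `CCc1nc2ccccc2c(=O)n1NC(=O)Nc1ccc(Cl)cc1`. The change is chloro in place of methyl on an aromatic carbon. For the measured compounds named here, nothing measured here links two compounds by a single such change, so there is no measured step to lean on. For compound 3 the expected step is no change at the digits printed from compound 2 to compound 3 (within the scatter), that is none beyond the scatter, since compound 1 and compound 2 both sit at the same inhibition. Compound 3 is therefore estimated at 55%, with a range from 40% to 70%.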

Compound 3, a percentage reported as inhibition, in the whole organism at one dose (the size of the read-out at that dose, not a potency): 52%
The estimate for compound 3 lay 3 percentage points above the measured number; measured number inside the range.
By their numbers in this assay, from the lowest: compounds 3, 1 and 2 (each within the scatter of the next).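

In this assay, going from 4-methylphenyl to 4-chlorophenyl gives a number 3 percentage points lower from compound 2 to compound 3 (within the scatter), so this exchange at the place para to a large group leaves no readable difference at this dose. Compound 3 also gives the first single-place link to compound 1, with ethyl in place of phenyl, and a number 3 percentage points lower from compound 1 to compound 3 (within the scatter) shows that this second change likewise stays within the scatter, whereas compounds 1 and 2 differed in two places and could not separate the changes. No measurement is at hand that would explain either result.

Going by these compounds, whether an amine or a carboxylic acid at the same place would move the inhibition remains open, as does the effect of a longer chain such as propyl in place of ethyl. With a single dose, these numbers also leave any difference in potency among the compounds unsettled.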